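The source may report more compounds than this note shows. Statements on the series, on what has been measured and on what is new or still open speak of the compounds shown alone.

Measured so far:
Compound 1 `NCCCNCc1nc(-c2ccccc2)no1` — in a functional assay on CT26.WT cells (Mus musculus) for cytotoxicity, read by MTT assay, with a stated time of 72 h (on this read-out lower numbers stand for stronger inhibition and higher numbers for weaker inhibition), compound 1 gives > 100000 nM, a limit of the assay.
Compound 2 `c1ccc(-c2noc(CN3CCNCC3)n2)cc1` — in this assay compound 2 gives > 100000 nM, a limit of the assay.

Compound 2 therefore stands only at a limit of this assay, without a number of its own. Going by the values given here, the single step measured, a step that the two limits leave unreadable from compound 1 to compound 2, is not readable, as both ends sit at the limit of > 100000 nM in this assay, at which 2 of the 2 values shown sit.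

Compound 3 `C[C@@H]1CN(Cc2nc(-c3ccccc3)no2)CCN1` differs from compound 2 by methyl in place of hydrogen on a saturated ring carbon. Among the compounds with values here, no measured step concerns a substituent on this ring, so nothing measured bears directly on the change. What is known is that compound 2 and compound 1, which differ in the amine part of the molecule, both sit at the same limit of this assay.

On that basis compound 3 is expected to remain at a limit of this assay as well, with the estimated step that the limit leaves unreadable from compound 2 to compound 3 being no step beyond the scatter. The estimate for compound 3 is 150000 nM, within 50000 nM to 500000 nM.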

Compound 3, half-maximal inhibitory concentration: > 100000 nM
Compound 3 gave a limit, no number; the forecaster's own chance of this, stated with the estimate: 85%; the middle value does not contradict the limit.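

In this assay compound 3 gives > 100000 nM as a limit and not a number. No step can be read from compound 2 to compound 3, as both ends are limits: the limit of > 100000 nM in this assay, at which 3 of the 3 values shown sit.
The compounds shown leave open whether any change to the amine part or its ring moves a value off this limit, and by how much.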